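The source may hold more compounds than are shown below. What is called first, only, known or untested is meant among the compounds shown, and "the series" means these compounds.

Measured so far in an assay on cells for inhibition of Palmitoleoyl-protein carboxylesterase NOTUM variant C330S (Homo sapiens), read by fluorescence, with a stated time of 40 min; a lower number here means a stronger inhibitor, a higher number a weaker inhibitor:

Compound 1, `O=C(O)C1CCN(c2ccccc2)C1`: 48000 nM
Compound 2, `O=C(O)C1CCN(c2ccccc2Cl)C1`: 19000 nM
Compound 3, `Cc1cc(C(=O)O)c(C)n1-c1cccc(Cl)c1`: 430 nM

Compound 1 and compound 2 share one core; compound 3 and the unmeasured compound 4, `Cc1cc(C(=O)O)c(C)n1-c1cc(Cl)ccc1Cl`, share another. The difference between the two cores is not broken down here. Compound 3 gives the lowest number of the three measured compounds, and its distance to both compound 2 and compound 1 lies beyond the scatter.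

Within the first pair the change is chloro in place of hydrogen on an aromatic carbon, and it gave a 2.5-fold lower number from compound 1 to compound 2 (0.40 log units; beyond the scatter). The change from compound 3 to compound 4 is chloro in place of hydrogen on an aromatic carbon. It is the same kind of change, not the same: in the first pair the place is ortho to a group of 8 heavy atoms, while in the second pair it is ortho to a large group and para to a chloro group, so the surroundings of the entering chloro are not identical. This change has been seen once among the measured compounds, on a core different from that of compound 3, so the transfer rests on a single measured step.

Taking that one step as the guide, compound 4 is expected to show a 2.2-fold lower number from compound 3 to compound 4 (0.33 log units; beyond the scatter) in this assay, because compound 2 shows a 2.5-fold lower number from compound 1 to compound 2 (0.40 log units; beyond the scatter) with the same kind of change. The estimate for compound 4 in this assay is 200 nM, with a range from 90 nM to 450 nM, and the number is awaited.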

Compound 4, half-maximal inhibitory concentration: 1700 nM
Compound 4: the middle estimate sits 8.5-fold (0.93 log units) below what was measured; measured number above the stated range.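

In this assay, chloro in place of hydrogen on the aromatic carbon ortho to a large group and para to a chloro group gives a 4.0-fold higher number from compound 3 to compound 4 (0.60 log units; beyond the scatter), so the step seen on the core of compound 1 did not carry over to the core of compound 3 in size or in direction: the same change on two cores in this assay, a 2.5-fold lower number (0.40 log units; beyond the scatter) from compound 1 to compound 2 and a 4.0-fold higher number (0.60 log units; beyond the scatter) from compound 3 to compound 4, 10-fold (1.00 log units) apart, beyond the scatter of two such steps

Within this series, then, the change cannot be treated as a fixed increment that moves from one core to the other, and a single measured step on one core does not even settle the sign of the step on another. What remains unshown is the source of the difference: the two pairs differ both in the core and in the surroundings of the entering chloro, and two steps cannot separate these or support a general rule for the series.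

The compounds shown leave open whether the higher number from the added chloro belongs to the core of compound 3 itself or to this particular place on the aromatic ring, para to a chloro group. They also leave open whether a fluoro or a methyl entering at the same place would move the number in the same direction as chloro.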